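The compounds below may be only part of what the source reports. "The series", "measured", "known", "first", "only" and "open" are said of these compounds alone.

Measured so far in a functional assay on PC-3 cells (Homo sapiens) for antiproliferative activity, read by MTT assay, with a stated time of 24 h; on this read-out higher numbers stand for weaker inhibition and lower numbers for stronger inhibition:
compound 1, `CCn1c(C(=O)NCCN)ccc1C(CC)(CC)c1ccc(OCS(=O)(=O)c2ccccc2)c(C)c1`, gives 6890 nM;
compound 2, `CCn1c(C(=O)N[C@H](C)CO)ccc1C(CC)(CC)c1ccc(OCS(=O)(=O)c2ccccc2)c(C)c1`, gives 7790 nM;
compound 3, `CCn1c(C(=O)NC2(CO)CC2)ccc1C(CC)(CC)c1ccc(OCS(=O)(=O)c2ccccc2)c(C)c1`, gives 3560 nM.

Compound 3 holds the lowest of the three numbers. Its distance from compound 1 stays within the scatter, and only the gap to compound 2 passes it, so its lead is slight.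

Compound 4, `CCn1c(C(=O)NCC(=O)O)ccc1C(CC)(CC)c1ccc(OCS(=O)(=O)c2ccccc2)c(C)c1`, is compound 3 with one change: carboxymethyl in place of 1-(hydroxymethyl)cyclopropyl on an amide-type nitrogen. The group with a three-membered ring goes, and a group with no ring comes in, as in compound 1 and compound 2. Going by the values given here, the steps that bear on this are a 1.9-fold lower number from compound 1 to compound 3 (0.29 log units; within the scatter) and a 2.2-fold lower number from compound 2 to compound 3 (0.34 log units; beyond the scatter), both showing that the ring-free groups go with higher numbers than compound 3, while a 1.1-fold higher number from compound 1 to compound 2 (0.05 log units; within the scatter) shows that exchanging one ring-free group for another barely moves the number. Among the compounds with values here, no measured compound carries a carboxymethyl group, so that part of the change is untested. Compound 4 is therefore expected to show a modest rise, a 2.1-fold higher number from compound 3 to compound 4 (0.32 log units; beyond the scatter). Compound 4 is estimated at 7500 nM, between 3500 nM and 16000 nM.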

Compound 4, half-maximal inhibitory concentration: 30100 nM
Compound 4: middle estimate off by 4.0-fold (0.60 log units), on the low side, and the stated range ends below it.
By their numbers in this assay, from the lowest: compounds 3, 1 and 2 (each within the scatter of the next, the first and the last beyond it); then compound 4.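

Swapping among the earlier groups on the amide-type nitrogen moved the number little, but carboxymethyl lifts it clearly against every one of them. The rise is largest against 1-(hydroxymethyl)cyclopropyl (an 8.5-fold higher number from compound 3 to compound 4 (0.93 log units; beyond the scatter)), and it also appears against the ring-free 1-(hydroxymethyl)ethyl (a 3.9-fold higher number from compound 2 to compound 4 (0.59 log units; beyond the scatter)) and against 2-aminoethyl, where carboxy replaces aminomethyl on the chain carbon (a 4.4-fold higher number from compound 1 to compound 4 (0.64 log units; beyond the scatter)), so ring-free groups at this place do not all behave alike. Nothing measured here explains why carboxymethyl stands apart.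

Open, going by these compounds, is whether a methyl ester or a primary amide in place of the carboxylic acid would bring the number back towards those of compound 1 and compound 2. Also open, on these data alone, is whether a longer chain ending in the carboxylic acid would behave like compound 4.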